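Methoxyphenyl amines on the shared core: moving the methoxy group

The compounds below may be only part of what the source reports. "The series", "measured", "known", "first", "only" and "open" are said of these compounds alone.

Compound 2 `COc1ccc(NC2=CC(=O)c3c(nc4n3[C@H]3OC[C@@H](O)[C@H]3OC4)C2=O)cc1` and compound 1 `COc1cccc(NC2=CC(=O)c3c(nc4n3[C@H]3OC[C@@H](O)[C@H]3OC4)C2=O)c1` share one core and differ only in the methoxyphenyl on the amine nitrogen. In a functional assay on ECa-109 cells for inhibition, with ECa-109 cell line (Homo sapiens) as the target, read by sulforhodamine B assay (a lower number here means a stronger inhibitor, a higher number a weaker inhibitor), compound 1 gives 3340 nM, and compound 2 gives 3410 nM; the step of a 1.0-fold higher number from compound 1 to compound 2 (0.01 log units; within the scatter) is within the scatter, so the two sit together. Compound 3 `COc1ccccc1NC1=CC(=O)c2c(nc3n2[C@H]2OC[C@@H](O)[C@H]2OC3)C1=O` continues this series: 2-methoxyphenyl in place of 4-methoxyphenyl on an amine nitrogen. Going by the values given here, the one step that bears on it, a 1.0-fold higher number from compound 1 to compound 2 (0.01 log units; within the scatter), showed no effect beyond the scatter from moving the methoxy group, so no step beyond the scatter is expected in this assay either way. Compound 3 is estimated at 3400 nM, range 1600 nM to 7500 nM, meaning an expected step of a 1.0-fold lower number from compound 2 to compound 3 (0.00 log units; within the scatter).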

Compound 3, half-maximal inhibitory concentration: > 4000 nM
Compound 3: only a limit was reported; the forecaster's own chance of this, stated with the estimate: 5%; middle value at least 1.1-fold (0.07 log units) from the limit.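

In this assay compound 3 gives > 4000 nM, which is a limit and not a number. With 2-methoxyphenyl on the amine nitrogen, the series now holds a value bounded from one side only: the limit of > 4000 nM in this assay, at which 1 of the 3 values shown sits. The steps, an at least 1.1-fold higher number from compound 2 to compound 3 (0.06 log units; that floor lies within the scatter) and an at least 1.1-fold higher number from compound 1 to compound 3 (0.07 log units; that floor lies within the scatter), have floors within the scatter, so this change may do nothing or may weaken inhibition by an unknown amount.

Still open, going by these compounds, is whether a different substituent on the phenyl ring, such as chlorine, a hydroxyl or a dimethylamino group, moves the number beyond the scatter.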